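The compounds below may be only part of what the source reports. "The series", "measured", "known", "first", "only" and "open" are said of these compounds alone.

Measured compounds in a functional assay on MCF7 cells (Homo sapiens) for antiproliferative activity, read by MTT assay, with a stated time of 72 h; a higher number here means a weaker inhibitor, a lower number a stronger inhibitor:
compound 1 `COc1cc(-n2cnc3ccc(-c4ccc([N+](=O)[O-])cc4)cc32)cc(OC)c1OC` gives 740 nM
compound 2 `COc1cc(-n2cnc3ccc(-c4ccc(C(F)(F)F)cc4)cc32)cc(OC)c1OC` gives 760 nM
compound 3 `COc1ccccc1-c1ccc2ncn(-c3cc(OC)c(OC)c(OC)c3)c2c1` gives 1750 nM

Compound 3 gives the highest number of the three, set apart from the others by modest steps beyond the scatter: a 2.4-fold higher number from compound 1 to compound 3 (0.37 log units; beyond the scatter) and a 2.3-fold higher number from compound 2 to compound 3 (0.36 log units; beyond the scatter). Compounds 1 and 2 lie within the scatter of one another, a 1.0-fold higher number from compound 1 to compound 2 (0.01 log units; within the scatter).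

Compound 4 `COc1ccc(-c2ccc3ncn(-c4cc(OC)c(OC)c(OC)c4)c3c2)cc1F` keeps the shared core and differs from compound 3 only in the pendant phenyl: 3-fluoro-4-methoxyphenyl in place of 2-methoxyphenyl on an aromatic carbon.

The two measured steps into compound 3 both run from 4-nitrophenyl or 4-(trifluoromethyl)phenyl to 2-methoxyphenyl and raised the number. Compound 4 carries 3-fluoro-4-methoxyphenyl, which matches neither of those groups, so these steps bear on it only loosely. A modest lowering is expected, a 1.8-fold lower number from compound 3 to compound 4 (0.24 log units; within the scatter), with wide uncertainty. Compound 4 is estimated at 1000 nM, range 450 nM to 2300 nM.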

Compound 4, half-maximal inhibitory concentration: 520 nM
For compound 4 the middle estimate is 1.9-fold (0.28 log units) above the measured one, within the range that was stated.
By their numbers in this assay, from the lowest: compounds 4, 1 and 2 (each within the scatter of the next); then compound 3.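

Methoxy on the pendant phenyl does not by itself go with the higher number in this assay: there is a 3.4-fold lower number from compound 3 to compound 4 (0.53 log units; beyond the scatter) with 3-fluoro-4-methoxyphenyl in place of 2-methoxyphenyl. The new group also sits level with the two earlier groups, with a 1.5-fold lower number from compound 2 to compound 4 (0.16 log units; within the scatter) against 4-(trifluoromethyl)phenyl and a 1.4-fold lower number from compound 1 to compound 4 (0.15 log units; within the scatter) against 4-nitrophenyl, both within the scatter. Nothing measured here accounts for these steps.

On these data alone, whether the fluorine or the place of the methoxy drives the step from compound 3 stays open. So does how an amine or a carboxylic acid on the pendant phenyl would read out.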